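Notes on an aminomethylene lactone series, cytotoxicity readout

The source may hold more compounds than are shown below. What is called first, only, known or untested is meant among the compounds shown, and "the series" means these compounds.

Measured so far:
compound 1 `CCn1ncc2ccc(N/C(C)=C3\C(=O)C=C(C)OC3=O)cc21` — > 100000 nM
compound 2 `CC1=CC(=O)/C(=C(/C)Nc2ccc3cnn(Cc4ccc(C)cc4)c3c2)C(=O)O1` — > 100000 nM
compound 3 `CCn1nc2cc(N/C(C)=C3\C(=O)C=C(C)OC3=O)ccc2c1Cl` — 6250 nM

In an ADME assay on RAW264.7 cells (Mus musculus) for cytotoxicity, read by resazurin assay, with a stated time of 48 h (a lower number here means that less compound is tolerated, a higher number that more compound is tolerated), compound 1 reaches only a limit of the assay, > 100000 nM. Compound 2 likewise ends at a limit, > 100000 nM. Compound 3 alone gives a number, 6250 nM. Compound 1 and compound 2 differ by 4-methylphenyl in place of methyl on a saturated chain carbon bound to an aromatic nitrogen; the step that the two limits leave unreadable from compound 1 to compound 2 cannot be read because of the limit of > 100000 nM in this assay, at which 2 of the 3 values shown sit. The difference between the core of compound 1 and the core of compound 3 is not broken down here. Compound 4 `CC1=CC(=O)/C(=C(/C)Nc2ccc3c(Cl)n(Cc4ccc(C)cc4)nc3c2)C(=O)O1` differs from compound 3 by 4-methylphenyl in place of methyl on a saturated chain carbon bound to an aromatic nitrogen, the same change in the same place. For compound 4 the expected step is a 1.3-fold lower number from compound 3 to compound 4 (0.10 log units; within the scatter); this expectation rests on compound 3 at 6250 nM and on the earlier instance giving no readable size. The estimate for compound 4 is 5000 nM, expected between 1500 nM and 20000 nM.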

Compound 4, half-maximal cytotoxic concentration: > 100000 nM
Compound 4 ended at the assay's limit; the forecaster's own chance of this, stated with the estimate: 10%; at least 20-fold (1.30 log units) between middle value and limit.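

On the core of compound 3, 4-methylphenyl in place of methyl on a saturated chain carbon bound to an aromatic nitrogen gives an at least 16-fold higher number from compound 3 to compound 4 (1.20 log units; beyond the scatter) in this assay, so more compound is tolerated with this change on that core. Compound 4 stands at a limit of the assay, > 100000 nM, so only a minimum size is known, and the same change on the core of compound 1 cannot be read, as both partners end at the limit: the limit of > 100000 nM in this assay, at which 3 of the 4 values shown sit. Whether the change carries from one core to another is not shown, as only one readable instance stands.

Open, from the compounds shown here alone, is how an amine or a carboxylic acid in place of 4-methylphenyl would read in this assay on the core of compound 3.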